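Working notes: from compound 3 to compound 4

A few compounds are considered here, and "the series" means these few. Any claim that something is new, unique, unknown or untested is made for them only; others in the source may bear on it.

Measured so far in an in vitro functional assay on HEK293-A cells for antagonist activity at metabotropic glutamate receptor 5 (Rattus norvegicus), read by calcium flux; on this read-out lower numbers stand for stronger inhibition and higher numbers for weaker inhibition:
compound 1, `Cc1cccnc1NC(=O)c1cc(F)cc(C#N)c1`, gives > 30000 nM, which is a limit of the assay and not a number.
compound 2, `CC(C)(C)c1csc(NC(=O)c2cc(F)cc(C#N)c2)n1`, gives > 10000 nM, again a limit of the assay.
compound 3, `N#Cc1cc(F)cc(C(=O)Nc2ccccc2F)c1`, gives > 30000 nM, also a limit of the assay.

Where compound 3 stands: no number is available for it, only a limit. It sits at the limit of > 30000 nM in this assay, at which 2 of the 3 values shown sit. The remaining value sits at the limit of > 10000 nM in this assay, at which 1 of the 3 values shown sits. Among the measured compounds shown here, none of the three compounds differs from another in a single place, so no measured step exists in the set, and nothing shows whether any of them is separated from another beyond the scatter.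

Compound 4, `Cc1ccccc1NC(=O)c1cc(F)cc(C#N)c1`, has not yet been run in this assay. Against compound 3 the change is methyl in place of fluoro on an aromatic carbon, a swap of one heavy atom for another at the same aromatic carbon. For the measured compounds named here, with no measured step to lean on, and because compound 3 gives only > 30000 nM, the expectation is that compound 4 will again return a limit rather than a number, with a number no higher from compound 3 to compound 4 (the limit leaves the size open) expected to be none beyond the scatter. The estimate for compound 4 is 30000 nM, with a range from 8000 nM to 100000 nM.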

Compound 4, half-maximal inhibitory concentration: > 30000 nM
Compound 4: a limit, no number (the forecaster's own chance of this, stated with the estimate: 75%); the middle value lies on the limit itself.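

Compound 3 and compound 4 each return only a limit of the assay in this assay, so no step can be read for methyl in place of fluoro. The compounds shown leave open whether any change to the shared core gives a number rather than a limit in this assay, and how large such a change would have to be.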